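This account rests on a few compounds, and the source may have more. Where it says the series, first, only, none or still open, it means among the compounds named here.

Of the compounds shown here, three built on one shared core have been measured in a functional assay on MKN-74 cells (Homo sapiens) for antiproliferative activity, with a stated time of 24 h; a higher number here means a weaker inhibitor, a lower number a stronger inhibitor. Compound 1, `Cc1ccccc1CN1CCc2c(sc(NC(=O)c3ccccc3Cl)c2C(N)=O)C1`, reaches only a limit of the assay, reported as > 50000 nM. Compound 2, `NC(=O)c1c(NC(=O)c2ccccc2Cl)sc2c1CCN(Cc1cc(Cl)cc(Cl)c1)C2`, gives 23700 nM. Compound 3, `NC(=O)c1c(NC(=O)c2ccccc2Cl)sc2c1CCN(C(=S)Nc1ccccc1Br)C2`, gives 10800 nM, which is the lowest of the two real numbers shown; its nearest neighbour is compound 2, separated by a 2.2-fold lower number from compound 2 to compound 3 (0.34 log units; beyond the scatter). The step of an at least 4.6-fold lower number from compound 1 to compound 3 (0.66 log units; beyond the scatter) is larger still, though its starting point is only a limit (the limit of > 50000 nM in this assay, at which 1 of the 3 values shown sits).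

Compound 4, `Cc1ccccc1NC(=S)N1CCc2c(sc(NC(=O)c3ccccc3Cl)c2C(N)=O)C1`, differs from compound 3 in one place: methyl in place of bromo on an aromatic carbon, sitting on the ring carried by the thiourea. Among the compounds with values here, no measured step swaps bromo for methyl directly. The closest comparisons are an at least 2.1-fold lower number from compound 1 to compound 2 (0.32 log units; beyond the scatter) and an at least 4.6-fold lower number from compound 1 to compound 3 (0.66 log units; beyond the scatter), where the only methyl-bearing ring, on compound 1, sits at a limit, while both halogen-bearing rings give lower numbers. Those steps also change the linker, so they bear on the present change only loosely.

Compound 4 is therefore expected to show a somewhat higher number than compound 3, a step of a 1.9-fold higher number from compound 3 to compound 4 (0.27 log units; within the scatter), with real chance that it, too, ends at a limit. The estimate for compound 4 is 20000 nM, expected to fall between 8000 nM and 50000 nM.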

Compound 4, half-maximal inhibitory concentration: 11700 nM
For compound 4 the middle estimate is 1.7-fold (0.23 log units) above the measured one, and the stated range covers the measured number.
By their numbers in this assay, from the lowest: compounds 3 and 4 (each within the scatter of the next); then compound 2. At a limit, above all of these: compound 1.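

In this assay, within the data shown here, the first direct swap at this spot, methyl in place of bromo on an aromatic carbon ortho to a large group, gives a 1.1-fold higher number from compound 3 to compound 4 (0.03 log units; within the scatter), so the two groups cannot be told apart here. Keeping 2-methylphenyl while changing what joins it to the amine nitrogen in the ring gives an at least 4.2-fold lower number from compound 1 to compound 4 (0.63 log units; beyond the scatter), so this ring does not by itself go with a weak result, although the step starts from a value that is only a limit for compound 1: the limit of > 50000 nM in this assay, at which 1 of the 4 values shown sits. Compound 4 also differs from the 3,5-dichlorophenyl compound, with a 2.0-fold lower number from compound 2 to compound 4 (0.31 log units; beyond the scatter), a modest step in which the ring substituents and the link change together, so neither change can be credited alone.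

The compounds shown leave open whether this insensitivity extends beyond bromo and methyl, for example to a hydroxyl, a methoxy group or a carboxylic acid on the same ring carbon. They also leave open how the thiourea link itself compares with a urea or an amide while the aromatic ring stays the same.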